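Swapping 4-phenylphenyl for naphthalen-2-yl: expected tolerability

The source may hold more compounds than are shown below. What is called first, only, known or untested is meant among the compounds shown, and "the series" means these compounds.

Two compounds have been measured in an ADME assay on MT4 cells (Homo sapiens) for cytotoxicity, read by MTT assay, with a stated time of 5 days; a lower number here means that less compound is tolerated, a higher number that more compound is tolerated:
Compound 1, `COc1ccc(-c2cnc(Nc3ccc(C#N)cc3)nc2Oc2c(C)cc(C#N)cc2C)cc1`, gives > 279000 nM, which is a limit of the assay.
Compound 2, `Cc1cc(C#N)cc(C)c1Oc1nc(Nc2ccc(C#N)cc2)ncc1-c1ccc(-c2ccccc2)cc1`, gives > 253000 nM, which is a limit of the assay.

Compound 2 therefore stands at a limit of this assay, not at a measured number, and the same holds for the other value shown, so compound 2 cannot be placed above or below compound 1. Going by the values given here, the only step between measured compounds, a step that the two limits leave unreadable from compound 1 to compound 2, is unreadable for the same reason; neither the limit of > 253000 nM in this assay, at which 1 of the 2 values shown sits, nor the limit of > 279000 nM in this assay, at which 1 of the 2 values shown sits, gives a number to work from.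

Compound 3, `Cc1cc(C#N)cc(C)c1Oc1nc(Nc2ccc(C#N)cc2)ncc1-c1ccc2ccccc2c1`, differs from compound 2 in one place: naphthalen-2-yl in place of 4-phenylphenyl on an aromatic carbon. Among the compounds with values here, no measured step bears on this change, so no step beyond the scatter is expected; the most likely outcome is that compound 3 again reaches only a limit. Compound 3 is estimated at 250000 nM, with a range of 100000 nM to 300000 nM, meaning an expected step of an at least 1.0-fold lower number from compound 2 to compound 3 (0.00 log units; that floor lies within the scatter).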

Compound 3, half-maximal cytotoxic concentration: 8460 nM
The estimate for compound 3 lay 30-fold (1.47 log units) above the measured number; measured number outside the range, below it.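

In this assay compound 3 is the first compound shown to give a number rather than a limit, so the group at this position of the shared core can change how much compound the cells tolerate. Although 4-phenylphenyl and naphthalen-2-yl each hold two six-membered aromatic rings of carbon only, the swap gives an at least 29-fold lower number from compound 2 to compound 3 (1.47 log units; beyond the scatter), and replacing 4-methoxyphenyl gives an at least 32-fold lower number from compound 1 to compound 3 (1.51 log units; beyond the scatter). The first of these steps is a floor, not an exact size, because compound 2 stands at a limit: the limit of > 253000 nM in this assay, at which 1 of the 3 values shown sits.

The step between compound 1 and compound 2 cannot be read, so those two cannot be ordered. On these data alone, whether other fused aromatic rings lower the number in the same way, or whether an amine or a carboxylic acid at this position would do so, remains open.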